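This account rests on a few compounds, and the source may have more. Where it says the series, first, only, none or still open, it means among the compounds named here.

In a functional assay on HeLa cells (Homo sapiens) for antiproliferative activity, read by MTT assay, with a stated time of 48 h (a higher number here means a weaker inhibitor, a lower number a stronger inhibitor), compound 1 (`COc1ccc(C(=O)c2ccc3c(c2)C=CC(C)(C)O3)c(NC(=O)CBr)c1`) gives 3050 nM while compound 2 (`COc1ccc(C(=O)c2ccc3c(c2)C=CC(C)(C)O3)c(NC(=O)CO)c1`) gives 240 nM and compound 3 (`COc1ccc(C(=O)c2ccc(OC)c3c2OC(C)(C)C=C3)c(NC(=O)CN)c1`) gives 410 nM in the same test. Compound 2 therefore sits at the low end of these numbers, and its value and that of compound 3 lie within the usual scatter of each other.

Compound 4 (`COc1ccc(C(=O)c2ccc3c(c2)C=CC(C)(C)O3)c(NC(=O)CN)c1`) keeps the core of compound 2 and changes a single group, with amino in place of hydroxy on a saturated chain carbon bound to a carbonyl carbon. Within the data shown here, the one measured step at this same carbon, hydroxy in place of bromo, is large (a 13-fold lower number from compound 1 to compound 2 (1.10 log units; beyond the scatter)). It starts from bromo, however, so it does not compare amino with hydroxy directly. Compound 3 offers a closer hint, since it carries amino at that carbon, though on a different core, and still reaches 410 nM in this assay without leaving the scatter around compound 2. Among the measured compounds shown here, no measured pair compares the two groups on one core, so the estimate stays uncertain.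

A small step is expected (a 1.3-fold higher number from compound 2 to compound 4 (0.10 log units; within the scatter)), towards a slightly higher number and not beyond the scatter. For compound 4 the estimated value is 300 nM with an expected range from 100 nM to 900 nM in this assay.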

Compound 4, half-maximal inhibitory concentration: 580 nM
Compound 4: middle estimate off by 1.9-fold (0.29 log units), on the low side; low and high end bracket the measured number.
By their numbers in this assay, from the lowest: compounds 2, 3 and 4 (each within the scatter of the next, the first and the last beyond it); then compound 1.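

On the shared core, hydroxy and amino at this saturated chain carbon bound to a carbonyl carbon can now be compared directly in this assay: the change to amino gives a 2.4-fold higher number from compound 2 to compound 4 (0.38 log units; beyond the scatter) and so has a real, if modest, effect, even though the computed counts of hydrogen-bond donors and acceptors and the net charge are the same for the two groups. Amino in place of bromo gives a 5.3-fold lower number from compound 1 to compound 4 (0.72 log units; beyond the scatter) on the same core, so both replacements of bromo shown here lower the number, and among these three groups bromo stands at the high end. Nothing measured here explains why hydroxy and amino differ at this carbon.

As far as these compounds go, whether the gap between hydroxy and amino carries over to another core stays open, since the only other core here, in compound 3, appears with amino alone. Also open, from the compounds shown here alone, is how this carbon would respond to a methoxy group, a dimethylamino group, a carboxylic acid or a longer chain such as hydroxyethyl.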